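A Chlorophenyl Swap on the Triazole Nitrogen

The compounds below may be only part of what the source reports. "The series", "measured", "known", "first", "only" and "open" are said of these compounds alone.

In a functional assay on HCT-116 cells (Homo sapiens) for antiproliferative activity, read by MTT assay, with a stated time of 48 h (on this read-out higher numbers stand for weaker inhibition and lower numbers for stronger inhibition), compound 3 `CCc1ccccc1-n1nncc1CN1C(=O)C2(C(C#N)=C(N)Oc3c(N)cc4nc5ccccc5nc4c32)c2ccccc21` gives 10300 nM. Within the data shown here, this is the only number among the three measured compounds; the other two sit at a limit of the assay. Compound 1 `Cc1cc(C)cc(-n2nncc2CN2C(=O)C3(C(C#N)=C(N)Oc4c3c3nc5ccccc5nc3c3ccccc43)c3ccccc32)c1` gives > 50000 nM, a limit and not a number. Compound 2 `Cc1cccc(-n2nncc2CN2C(=O)C3(C(C#N)=C(N)Oc4c(N)cc5nc6ccccc6nc5c43)c3ccccc32)c1` gives > 50000 nM, again a limit. Among the measured compounds shown here, the one measured step is an at least 4.8-fold lower number from compound 2 to compound 3 (0.68 log units; beyond the scatter), and it bears on the change now considered, as the group on the aromatic nitrogen is exchanged once more. Compound 4 `N#CC1=C(N)Oc2c(N)cc3nc4ccccc4nc3c2C12C(=O)N(Cc1cnnn1-c1ccc(Cl)cc1)c1ccccc12` differs from compound 3 in that (4-chlorophenyl in place of 2-ethylphenyl on an aromatic nitrogen). Two of the three values shown rest at the limit of > 50000 nM in this assay, at which 2 of the 3 values shown sit, and only the 2-ethylphenyl of compound 3 yielded a number, so a phenyl carrying instead a chlorine is expected to move the number upward, with a fair chance that this assay again reports only a limit. Compound 4 is therefore expected to give 25000 nM in this assay, within 8000 nM to 60000 nM, an expected 2.4-fold higher number from compound 3 to compound 4 (0.39 log units; beyond the scatter).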

Compound 4, half-maximal inhibitory concentration: > 50000 nM
Compound 4 gave a limit, no number; the forecaster's own chance of this, stated with the estimate: 45%; middle value at least 2.0-fold (0.30 log units) away from the limit.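

In this assay, among these compounds, 4-chlorophenyl in place of 2-ethylphenyl on this aromatic nitrogen gives an at least 4.8-fold higher number from compound 3 to compound 4 (0.68 log units; beyond the scatter), so a change confined to the phenyl group is enough to lose the only measured number in the set. The value of compound 4 is a limit and not a number, and the step between compound 2 and compound 4 cannot be read, as both values are limits. Among the compounds that share this core, compound 3 is now the only one to escape the limit, and its 2-ethylphenyl group is the exception here: the limit of > 50000 nM in this assay, at which 3 of the 4 values shown sit.

The compounds shown leave open whether the number of compound 3 depends on the ethyl group itself or on where it sits on the phenyl ring. A 4-ethylphenyl or 2-chlorophenyl group on this nitrogen would separate those two readings.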